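The compounds below may be only part of what the source reports. "The series", "measured", "known", "first", "only" and "open" are said of these compounds alone.

Measured compounds:
compound 1 `COc1ccccc1-n1c(Nc2nc(-c3ccc([N+](=O)[O-])cc3)cs2)n[nH]c1=S` — 100 mg/kg
compound 2 `O=[N+]([O-])c1ccc(-c2csc(Nc3n[nH]c(=S)n3-c3ccccc3)n2)cc1` — 300 mg/kg
compound 3 `S=c1[nH]nc(Nc2nc(-c3ccc(Cl)cc3)cs2)n1-c1ccccc1` — 300 mg/kg

All three share one core and were tested in a functional assay on the whole organism (strain Swiss albino) for inhibition, with Mus musculus as the target, with a stated time of 4 h; on this read-out lower numbers stand for an effect already at smaller amounts and higher numbers for an effect only at larger amounts of compound. Compound 2 gives 300 mg/kg and compound 3 gives 300 mg/kg; the two stand level, as no change at the digits printed from compound 2 to compound 3 (within the scatter) shows, and the change between them is chloro in place of nitro on an aromatic carbon. Compound 1, in contrast, gives 100 mg/kg, which is a 3.0-fold lower number from compound 2 to compound 1 (0.48 log units; beyond the scatter); the change here is methoxy in place of hydrogen on an aromatic carbon.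

Compound 4 `COc1ccccc1-n1c(Nc2nc(-c3ccc(Cl)cc3)cs2)n[nH]c1=S` is not yet measured. It differs from compound 3 by methoxy in place of hydrogen on an aromatic carbon, the same change that was made from compound 2 to compound 1; the place is described in identical words for both pairs. The cores of compound 3 and compound 2 differ by chloro in place of nitro on an aromatic carbon.

For compound 4 in this assay a step of a 3.0-fold lower number from compound 3 to compound 4 (0.48 log units; beyond the scatter) is expected, resting on the earlier step of a 3.0-fold lower number from compound 2 to compound 1 (0.48 log units; beyond the scatter) seen for the same change, with the caveat that it is a single precedent. Compound 4 is therefore estimated at 100 mg/kg, with a range from 50 mg/kg to 300 mg/kg.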

Compound 4, minimum effective dose: 100 mg/kg
Estimate against measurement, compound 4: no gap at the digits printed; the range from low to high includes it.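

In this assay, methoxy in place of hydrogen on the core carrying chloro gives a step (a 3.0-fold lower number from compound 3 to compound 4 (0.48 log units; beyond the scatter)) that matches the one on the core carrying nitro: the same change on two cores in this assay, a 3.0-fold lower number (0.48 log units; beyond the scatter) from compound 2 to compound 1 and a 3.0-fold lower number (0.48 log units; beyond the scatter) from compound 3 to compound 4, 1.0-fold (0.00 log units) apart, within the scatter of two such steps. Chloro in place of nitro gives a step within the scatter in the 2-methoxyphenyl pair (no change at the digits printed from compound 1 to compound 4 (within the scatter)), matching the result in the phenyl pair: the same change on two cores in this assay, no change at the digits printed (within the scatter) from compound 2 to compound 3 and no change at the digits printed (within the scatter) from compound 1 to compound 4, 1.0-fold (0.00 log units) apart, within the scatter of two such steps. Across these four compounds, the two changes therefore behave as independent of each other, but this rests on only two cores and does not show that the methoxy step would carry over to a core with any other group in place of chloro or nitro, nor does it give a reason for the step.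

On these data alone, it remains open whether an ethoxy group, a hydroxyl or an amine in place of the methoxy would give a comparable step. As far as these compounds go, it also remains open whether the chloro and nitro compounds would still stand level with a carboxylic acid or a longer chain in their place.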